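The compounds below may be only part of what the source reports. "The series", "measured", "known", "first", "only" and "open" are said of these compounds alone.

Compound 1, `COc1cc([C@@H]2[C@H](Oc3ccccc3)C(=O)N2c2cc(OC)c(OC)c(OC)c2)cc(OC)c1OC`, gives 29000 nM in a functional assay on MCF7 cells (Homo sapiens) for antiproliferative activity, read by MTT assay, with stated times of 24 h and 72 h; a lower number here means a stronger inhibitor, a higher number a weaker inhibitor. Compound 2, `COc1cc(N2C(=O)[C@@H](Oc3ccccc3)[C@H]2c2ccc(O)c(O)c2)cc(OC)c1OC`, gives 4500 nM.

Within the data shown here, compound 2 shows the lowest of the two numbers; the only measured step, a 6.4-fold lower number from compound 1 to compound 2 (0.81 log units; beyond the scatter), separates it from compound 1. Compound 3, `COc1cc(N2C(=O)[C@@H](Oc3ccccc3)[C@H]2c2cccc(N)c2)cc(OC)c1OC`, differs from compound 2 in one place: 3-aminophenyl in place of 3,4-dihydroxyphenyl on a saturated ring carbon. Among the measured compounds shown here, no measured step swaps these two groups, so the single step from compound 1 to compound 2 only shows that the group on this saturated ring carbon can shift the number modestly. Compound 3 is therefore expected to stay close to compound 2, with a 1.3-fold higher number from compound 2 to compound 3 (0.12 log units; within the scatter) not clearly beyond the scatter. The estimate for compound 3 is 6000 nM, between 1500 nM and 25000 nM.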

Compound 3, half-maximal inhibitory concentration: 17000 nM
The estimate for compound 3 lay 2.8-fold (0.45 log units) below the measured number; the range from low to high includes it.
By their numbers in this assay, from the lowest: compound 2; then compounds 3 and 1 (each within the scatter of the next).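

In this assay, the saturated ring carbon now separates two groups that each carry a six-membered aromatic ring of carbon only: with a 3.8-fold higher number from compound 2 to compound 3 (0.58 log units; beyond the scatter), 3-aminophenyl does not keep the number given by 3,4-dihydroxyphenyl. With a 1.7-fold lower number from compound 1 to compound 3 (0.23 log units; within the scatter), 3-aminophenyl and 3,4,5-trimethoxyphenyl are not told apart, so among these three groups only 3,4-dihydroxyphenyl stands apart. No supporting data are available to explain this difference. Going by these compounds, whether 3-hydroxyphenyl at this carbon would stay with compound 2 or with compound 3 remains open.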